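The source may report more compounds than this note shows. Statements on the series, on what has been measured and on what is new or still open speak of the compounds shown alone.

Measured so far in an assay on isolated protein for displacement of a labelled ligand from Alpha-1A adrenergic receptor (Homo sapiens); on this read-out lower numbers stand for stronger inhibition and higher numbers for weaker inhibition:
- compound 1, `O=C(NCCCCN1CCN(c2cccc(Cl)c2)CC1)c1ccc2ccccc2c1`: 50.2 nM
- compound 2, `COc1ccccc1N1CCN(CCCCNC(=O)CC(C)C)CC1`: 418 nM

Of the two compounds measured, compound 2 gives the higher number, 418 nM, which on this read-out means the weaker binding. Compound 1 gives 50.2 nM, a number far enough below that of compound 2 to lie beyond the usual scatter of repeated measurements. The two compounds differ in more than one place, so no single change can be held responsible for that gap; what can be said is that the compound carrying an aromatic ring on its carbonyl carbon is the one with the stronger binding.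

Compound 3, `COc1ccccc1N1CCN(CCCCNC(=O)N(C)c2ccccc2)CC1`, has not yet been measured. Compared with compound 2 the change is methyl(phenyl)amino in place of isobutyl on a carbonyl carbon. Both groups carry no hydrogen-bond donors or acceptors, so the change is chiefly one of size and of a ring replacing a branched chain. Because compound 1 gives 50.2 nM with an aromatic ring on its carbonyl, an expected step towards a lower number, of moderate size and beyond the scatter, is estimated as a 2.8-fold lower number from compound 2 to compound 3 (0.45 log units; beyond the scatter). Compound 3 is therefore expected to give about 150 nM, within a range from 40 nM to 600 nM.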

Compound 3, inhibition constant: 116 nM
Beside the measured number, compound 3's estimate is 1.3-fold (0.11 log units) above it; the range from low to high includes it.
By their numbers in this assay, from the lowest: compound 1; then compound 3; then compound 2.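

In this assay, methyl(phenyl)amino in place of isobutyl on a carbonyl carbon gives a 3.6-fold lower number from compound 2 to compound 3 (0.56 log units; beyond the scatter). For the compounds shown here, this is the first comparison here in which only one place changes, so this gap can be tied to a single change and shows that the number responds to what sits at this position. The entering group brings more heavy atoms, a six-membered aromatic ring of carbon only and a nitrogen, while both groups carry 0 hydrogen-bond donors and 0 hydrogen-bond acceptors, and nothing measured here explains the step or says which of these differences matters.

One pair cannot separate these features: a benzyl group on the carbonyl carbon would keep a ring without the nitrogen, whereas a dimethylamino group would keep the nitrogen without the ring. Going by these compounds, it also remains open whether a larger group, such as a naphthyl ring or a longer chain on that nitrogen, would move the number further in the same direction or reverse it.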